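Swapping an Ethyl Group for Two Methyls

The source may report more compounds than this note shows. Statements on the series, on what has been measured and on what is new or still open speak of the compounds shown alone.

Going by the values given here, in a functional assay on HT-29 cells (Homo sapiens) for antiproliferative activity, read by sulforhodamine B assay, with a stated time of 48 h (on this read-out higher numbers stand for weaker inhibition and lower numbers for stronger inhibition), compound 1 `CCc1ccccc1NS(=O)(=O)c1ccc(N2CCNC2=O)cc1` gives 240 nM, the highest of the two numbers measured so far. Among the compounds with values here, compound 2 `O=C1NCCN1c1ccc(S(=O)(=O)Nc2cccc(Br)c2)cc1` gives 77 nM, and the only measured step is a 3.1-fold lower number from compound 1 to compound 2 (0.49 log units; beyond the scatter). Compound 3 `Cc1ccc(NS(=O)(=O)c2ccc(N3CCNC3=O)cc2)c(C)c1` differs from compound 1 by 2,4-dimethylphenyl in place of 2-ethylphenyl on a sulfonamide nitrogen. The measured step exchanged the 2-ethylphenyl for a 3-bromophenyl, a different kind of change, so it offers only a loose guide. A step of a 1.2-fold lower number from compound 1 to compound 3 (0.08 log units; within the scatter) is expected, not beyond the scatter. Compound 3 is therefore estimated at 200 nM, with a range from 70 nM to 600 nM.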

Compound 3, half-maximal inhibitory concentration: 180 nM
Estimate against measurement, compound 3: 1.1-fold (0.05 log units) above; measured number inside the range.
By their numbers in this assay, from the lowest: compound 2; then compounds 3 and 1 (each within the scatter of the next).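

With the same atoms joined differently, 2,4-dimethylphenyl in place of 2-ethylphenyl gives a 1.3-fold lower number from compound 1 to compound 3 (0.12 log units; within the scatter) and so cannot be told apart from the original group at this sulfonamide nitrogen. The step of a 2.3-fold higher number from compound 2 to compound 3 (0.37 log units; beyond the scatter) shows that the 3-bromophenyl still stands apart from both groups made only of carbon and hydrogen. Nothing measured here explains either step.

Going by these compounds, what an amine or a carboxylic acid on this phenyl group would do to the number stays open.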